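The source may report more compounds than this note shows. Statements on the series, on what has been measured and on what is new or still open speak of the compounds shown alone.

Measured so far in a functional assay on HUVEC cells (Homo sapiens) (a lower number here means that less compound is needed, a higher number that more compound is needed for the effect), each value a limit and not a number:
Compound 1 `COC1=C(C)C(=O)/C(=C(O)/C=C/c2ccc(Br)cc2)C(=O)C1(C)C`: < 4 ug/mL
Compound 2 `COC1=C(C)C(=O)/C(=C(O)/C=C/c2ccc(C)cc2)C(=O)C1(C)C`: < 4 ug/mL
Compound 3 `COC1=C(C)C(=O)/C(=C(O)/C=C/c2cc(C)cc(C)c2)C(=O)C1(C)C`: < 4 ug/mL

Compound 3 has no exact value on the numbers shown. In this assay compound 3 gives < 4 ug/mL, which is a limit. The two other compounds sit at the same limit, so no order can be drawn among the three.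

The next structure is compound 4 `C=Cc1ccccc1/C=C/C(O)=C1/C(=O)C(C)=C(OC)C(C)(C)C1=O`, with the change (2-vinylphenyl in place of 3,5-dimethylphenyl on a double-bonded chain carbon bound to a double-bonded chain carbon). The aryl group is exchanged on a double-bonded chain carbon bound to a double-bonded chain carbon, and the heavy-atom count stays the same.

Within the data shown here, two measured steps bear on this exchange at the same place: a step that the two limits leave unreadable from compound 1 to compound 3 and a step that the two limits leave unreadable from compound 2 to compound 3. Neither gives a size to carry over because of the limit of < 4 ug/mL in this assay, at which 3 of the 3 values shown sit. The remaining step, a step that the two limits leave unreadable from compound 1 to compound 2, is equally unreadable. The three compounds do show that three different aryl groups at this place all stay at the limit, though none of them carries the 2-vinylphenyl group.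

No step beyond the scatter is therefore expected in this assay, and no direction can be assigned. The expected step is a step that the limit leaves unreadable from compound 3 to compound 4. Compound 4 is expected at 2.5 ug/mL, with an estimated range from 0.6 ug/mL to 8 ug/mL.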

Compound 4, concentration for half-maximal effect: < 1.1 ug/mL
Compound 4: no number, only a limit; the forecaster's own chance of this, stated with the estimate: 75%; middle value at least 2.2-fold (0.35 log units) away from the limit.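

In this assay compound 4 gives < 1.1 ug/mL, which is a limit and not a number. No step to compound 4 from compound 1, compound 2 or compound 3 can be read, because each of the four values is a limit: the limit of < 4 ug/mL in this assay, at which 3 of the 4 values shown sit.

The compounds shown leave open whether the four aryl groups differ at all in this assay, and by how much.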